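Pyrazole acetonitriles on K562 cells: a methyl-to-hydrogen step

The source may hold more compounds than are shown below. What is called first, only, known or untested is meant among the compounds shown, and "the series" means these compounds.

Compound 1 `COc1cc(C)cc(-c2nn(CC#N)cc2-c2ccc(-c3cccc(C(C)=O)c3)nc2)c1` gives 5% in a functional assay on K562 cells (Homo sapiens) for cytotoxicity, read by sulforhodamine B assay, with a stated time of 48 h, tested at 1 uM; a higher number here means a weaker effect of the compound at the concentration tested, a lower number a stronger effect.
Compound 2 `Cc1cc(O)cc(-c2nn(CC#N)cc2-c2ccnc(-c3ccc(Oc4ccccc4)cc3)c2)c1` gives -13% in this assay.
Compound 3 `COc1cc(C)cc(-c2nn(CC#N)cc2-c2ccnc(-c3ccc(N(C)C)cc3)c2)c1` gives 4% in this assay.

Of the three numbers, compound 3 stands second highest. Compound 1 lies closest to it, one point higher, a gap within the usual scatter, so the two cannot be set in order. Compound 2 lies furthest, with a lower number and a gap beyond the scatter, so compound 2 shows the stronger effect of the pair at this concentration.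

Compound 4 `Cc1cc(O)cc(-c2nn(CC#N)cc2-c2ccnc(-c3ccc(N(C)C)cc3)c2)c1` has not yet been measured. It differs from compound 3 by hydrogen in place of methyl on an oxygen on an aromatic ring. No pair of measured compounds differs in that place alone, so the size of this step is not known from the data shown. Compound 2 also carries a hydroxy group and gives the lowest number, but it differs from the others in more than one place, so it cannot settle the step.

The step from compound 3 to compound 4 is expected to be small, a number 4 percentage points lower from compound 3 to compound 4 (within the scatter), not clearly beyond the scatter. Compound 4 is therefore estimated at 0%, within a range from -15% to 14%.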

Compound 4, a percentage reported as activity, at one concentration (the size of the read-out at that concentration, not a potency): 7%
Estimate against measurement, compound 4: 7 percentage points below, within the range that was stated.
By their numbers in this assay, from the lowest: compound 2; then compounds 3, 1 and 4 (each within the scatter of the next).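

In this assay, the change from methoxy to hydroxy on the 3-methoxy-5-methylphenyl group gives a number 3 percentage points higher from compound 3 to compound 4 (within the scatter), so with dimethylamino present, this exchange of methyl for hydrogen on the oxygen has no effect that can be told from the scatter. The second step keeps the hydroxy group and places dimethylamino in place of phenoxy on an aromatic carbon, giving a number 20 percentage points higher from compound 2 to compound 4 (beyond the scatter), so the low number of compound 2 goes with its phenoxy group and not with the hydroxy group it shares with compound 4. Nothing measured here explains either step.

As far as these compounds go, it remains open whether methoxy to hydroxy would stay as small a step in a compound carrying phenoxy. The compounds shown also leave open how a longer chain on that oxygen, such as ethoxy or propoxy, or an amine in place of the oxygen would read at this concentration.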